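Aniline series: shortening the chain and adding chlorine

This account rests on a few compounds, and the source may have more. Where it says the series, first, only, none or still open, it means among the compounds named here.

Measured so far:
compound 1, `C=C(Br)C(=O)Nc1cccc(-c2cn3nc(-c4ccccc4)sc3n2)c1` — 960 nM in a functional assay on CCRF-CEM cells (Homo sapiens) for inhibition, read by cell counting, with a stated time of 3 days; a higher number here means a weaker inhibitor, a lower number a stronger inhibitor
compound 2, `Nc1cccc(-c2cn3nc(CCc4ccccc4)sc3n2)c1` — 30000 nM in this assay

Compound 2 gives the highest number of the two in this assay; its nearest neighbour is compound 1, which lies well beyond the scatter below it. For the measured compounds named here, compound 1 and compound 2 differ in more than one place, so only their two values can be compared and no single step is derived from them.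

Compound 3, `Nc1cccc(-c2cn3nc(Cc4ccc(Cl)cc4)sc3n2)c1`, is not yet measured. It differs from compound 2 in one place: 4-chlorophenyl in place of benzyl on a saturated chain carbon bound to an aromatic carbon. The change keeps the same count of heavy atoms and the same single six-membered aromatic ring, but swaps one chain carbon for a chlorine on the ring.

Going by the values given here, no step between two measured compounds bears on this change, so the direction is open. The working expectation is a step from compound 2 to compound 3 of a 2.0-fold lower number from compound 2 to compound 3 (0.30 log units; within the scatter) in this assay, small and perhaps within the scatter. Compound 3 is therefore estimated at 15000 nM in this assay, with a range from 4000 nM to 50000 nM.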

Compound 3, half-maximal inhibitory concentration: 42000 nM
Compound 3: the middle estimate sits 2.8-fold (0.45 log units) below what was measured; the range from low to high includes it.
By their numbers in this assay, from the lowest: compound 1; then compounds 2 and 3 (each within the scatter of the next).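

In this assay, for the compounds shown here, the exchange gives a 1.4-fold higher number from compound 2 to compound 3 (0.15 log units; within the scatter), the first single-place step. Placing 4-chlorophenyl in place of benzyl on a saturated chain carbon bound to an aromatic carbon therefore leaves compound 2 and compound 3 inseparable, even though the change moves one heavy atom from the chain to a chlorine on the ring. Nothing available explains this flat reading at the position, and no measurement bears on what the chain carbon or the chlorine contributes.

Still open, going by these compounds, is whether the shorter chain and the chlorine would each read the same alone, as compound 3 carries both changes at once, and whether a plain phenyl, a longer chain, a morpholine or a carboxylic acid on this carbon would move the number beyond the scatter. Also open is whether the same exchange would stay as flat on a compound carrying the bromoacrylamide of compound 1 instead of the free aniline amine, for which the compounds shown offer no single-place comparison.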